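A Methyl Step at the Limit of Cytotoxicity

The source may report more compounds than this note shows. Statements on the series, on what has been measured and on what is new or still open speak of the compounds shown alone.

In an ADME assay on HepG2 cells (Homo sapiens) for cytotoxicity, read by CellTiter-Glo and ATP content, with a stated time of 72 h (on this read-out higher numbers stand for an effect only at larger amounts of compound and lower numbers for an effect already at smaller amounts), compound 1 (`CS(=O)(=O)c1ccc(C(=O)N2CCC(C(=O)N3CCc4ccccc43)CC2)cc1[N+](=O)[O-]`) gives > 27000 nM as a limit and not as a number. Compound 2 (`CS(=O)(=O)c1ccc(C(=O)N2CCC(C(=O)N3CCN(c4ccc(F)cc4)CC3)CC2)cc1[N+](=O)[O-]`) gives > 27000 nM as a limit too. Compound 1 thus stands with compound 2 at the limit of > 27000 nM in this assay, at which 2 of the 2 values shown sit, and no number has been read for either. Compound 3 (`CC1Cc2ccccc2N1C(=O)C1CCN(C(=O)c2ccc(S(C)(=O)=O)c([N+](=O)[O-])c2)CC1`) differs from compound 1 by one change (methyl in place of hydrogen on a saturated ring carbon) with methyl in place of hydrogen on a saturated ring carbon, so that 2,3-dihydro-1H-indol-1-yl becomes 2-methyl-2,3-dihydro-1H-indol-1-yl. Within the data shown here, no measured step is available to size such a change. The expectation rests on compound 1, whose > 27000 nM is a limit. The expected a number no higher from compound 1 to compound 3 (the limit leaves the size open) in this assay lies within the scatter, and another limit is the likely report. For compound 3 the estimate is 27000 nM with 12000 nM to 35000 nM as its expected range.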

Compound 3, half-maximal effective concentration: > 27000 nM
Compound 3: no number, only a limit; the forecaster's own chance of this, stated with the estimate: 85%; the middle value lies on the limit itself.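

No step from compound 1 to compound 3 can be read, since both results are limits and not numbers: the limit of > 27000 nM in this assay, at which 3 of the 3 values shown sit.

The compounds shown leave open what methyl in place of hydrogen on a saturated ring carbon does to the read-out, and at what concentration any of them would reach a half-maximal effect.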